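Fused bicyclic esters with aryl variation: a cytotoxicity survey

This account rests on a few compounds, and the source may have more. Where it says the series, first, only, none or still open, it means among the compounds named here.

Compound 1 `CCOC(=O)C12C(=O)OCC=C1COC2c1ccccc1F` — in a functional assay on QGY cells (Homo sapiens) for cytotoxicity, read by MTT assay (on this read-out higher numbers stand for weaker inhibition and lower numbers for stronger inhibition), compound 1 gives > 1000000 nM, a limit of the assay.
Compound 2 `CCOC(=O)C12C(=O)OCC=C1COC2c1cccc(Cl)c1` — in this assay compound 2 gives > 1000000 nM, a limit of the assay.
Compound 3 `CCOC(=O)C12C(=O)OCC=C1COC2c1ccc(Cl)c(Cl)c1` — in this assay compound 3 gives > 1000000 nM, a limit of the assay.

Compound 2 therefore stands only at a limit, with no number of its own, and the two values shown beside it are limits as well (the limit of > 1000000 nM in this assay, at which 3 of the 3 values shown sit). Compound 4 `CCOC(=O)C12C(=O)OCC=C1COC2c1ccc(Br)cc1` differs from compound 2 by 4-bromophenyl in place of 3-chlorophenyl on a saturated ring carbon. For the measured compounds named here, the steps that bear on this change are a step that the two limits leave unreadable from compound 1 to compound 2 and a step that the two limits leave unreadable from compound 2 to compound 3; neither has a readable size, so no direction can be drawn from them. Compound 4 is therefore expected to sit at the same limit, with an estimated step that the limit leaves unreadable from compound 2 to compound 4. The estimate for compound 4 is 2000000 nM, in the range 500000 nM to 10000000 nM.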

Compound 4, half-maximal inhibitory concentration: > 1000000 nM
Compound 4: only a limit was reported (the forecaster's own chance of this, stated with the estimate: 85%); the middle value lies beyond the limit too.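

Compound 4 sits at the same limit of the assay as compound 1, compound 2 and compound 3, so no step among them can be read: the limit of > 1000000 nM in this assay, at which 4 of the 4 values shown sit.

What the compounds shown leave open is how any aryl group on the shared core affects cytotoxicity in this assay, since none has a number of its own.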